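Swapping a methyl for an oxolane ring on the side chain

A few compounds are considered here, and "the series" means these few. Any claim that something is new, unique, unknown or untested is made for them only; others in the source may bear on it.

Among the measured compounds shown here, compound 1 `Cc1cc(C)c(CN2CCc3c(Cl)cc([C@@H](C)CO)c(Cl)c3C2=O)c(=O)[nH]1` is the only compound here with a single number: in an assay for inhibition of histone-lysine N-methyltransferase EZH2 variant Y641N (Homo sapiens), read by scintillation counting, with a stated time of 60 min, in the presence of a further agent that is not named here (a lower number here means a stronger inhibitor, a higher number a weaker inhibitor), compound 1 gives 260 nM. A related compound, compound 2 `COC(c1cc(Cl)c2c(c1Cl)C(=O)N(Cc1c(C)cc(C)[nH]c1=O)CC2)C1CCOC1`, carries an oxolan-3-yl group together with a methoxy group on the same side chain; in this assay compound 2 gives 130 nM; 30 nM; 1.9 nM; 0.6 nM (4 entries), a set of repeat entries that spreads far wider than the usual scatter (the several entries of compound 2 in this assay, 130 nM; 30 nM; 1.9 nM; 0.6 nM (4 entries)). Compound 3 `Cc1cc(C)c(CN2CCc3c(Cl)cc([C@H](CO)[C@H]4CCOC4)c(Cl)c3C2=O)c(=O)[nH]1` has not yet been measured. It differs from compound 1 in one place (oxolan-3-yl in place of methyl on a saturated chain carbon bound to an aromatic carbon and a saturated chain carbon). For the measured compounds named here, no directly comparable measured pair exists, so the size of the step is a judgement. Given that compound 2 gives 130 nM; 30 nM; 1.9 nM; 0.6 nM (4 entries) in this assay, the step of an 8.7-fold lower number from compound 1 to compound 3 (0.94 log units; beyond the scatter) is expected to move toward stronger inhibition. Compound 3 is estimated at 30 nM, with a likely range from 5 nM to 150 nM.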

Compound 3, inhibition constant: 0.24 nM
Compound 3: the middle estimate sits 130-fold (2.10 log units) above what was measured; measured number below the stated range.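

In this assay, the place on a saturated chain carbon bound to an aromatic carbon and a saturated chain carbon holds much more than a methyl: the swap to oxolan-3-yl gives a 1100-fold lower number from compound 1 to compound 3 (3.03 log units; beyond the scatter). A single change here can therefore shift the number by a very large amount, though this rests on one pair of compounds. The earlier compounds could not fix the size of such a step, because the repeat entries of compound 2 do not settle on one level: the several entries of compound 2 in this assay, 130 nM; 30 nM; 1.9 nM; 0.6 nM (4 entries)

The compounds shown leave open whether the gain needs the ring oxygen, which a cyclopentyl group in the same place would test. They also leave open whether it depends on the defined stereocentre of the oxolan-3-yl group, which the opposite arrangement at that centre would test.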